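The compounds below may be only part of what the source reports. "The series", "measured", "known", "first", "only" and "open" are said of these compounds alone.

Working notes on the series. In an assay on HEK293 cells for agonist activity at Toll-like receptor 8 (Homo sapiens), read by reporter gene assay (a lower number here means that less compound is needed, a higher number that more compound is needed for the effect), compound 1 `CCCCCCn1c(N)nc2ccccc21` gives 3960 nM. Compound 2 `CCCCCn1c(N)nc2cccnc21` is reported in this assay as "not active" (no number reported), without a number. Compound 3 `CCCCCn1c(N)nc2c(C)cccc21` gives 1130 nM in this assay, the lowest of the two numbers reported; the number for compound 1 lies higher by a margin beyond the scatter. Compound 4 `CCCCCn1c(N)nc2c(Cl)cccc21` has not yet been measured in this assay. Compound 4 differs from compound 3 in one place: chloro in place of methyl on an aromatic carbon. Going by the values given here, no step between measured compounds touches this change, so nothing measured so far tells its size. The expected step is a 1.3-fold lower number from compound 3 to compound 4 (0.10 log units; within the scatter), which is none beyond the scatter in either direction. On that basis compound 4 is estimated at 900 nM, with a range from 300 nM to 3000 nM.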

Compound 4, half-maximal effective concentration: "not active" (no number reported)
Compound 4 has no reported number here; the estimate stays without a comparison.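

Going by these compounds alone, compound 4 carries no number in this assay, so no step from compound 3 to compound 4 can be read. Nothing at hand bears on this result. The compounds shown leave open how other groups on that aromatic carbon would fare.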